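The compounds below may be only part of what the source reports. "The series", "measured", "known", "first", "only" and "open" are said of these compounds alone.

In a functional assay on DWD cells (Homo sapiens) for inhibition, read by sulforhodamine B assay (on this read-out lower numbers stand for stronger inhibition of growth and higher numbers for weaker inhibition of growth), compound 1 (`Cc1ccc2[nH]c(-c3ccc(-c4ccc(-c5ccccc5)cc4)cc3)nc2c1`) gives 28300 nM, and compound 2 (`Cc1ccc2[nH]c(-c3ccc(-c4ccc(-c5ccc(F)cc5)cc4)cc3)nc2c1`) gives 33100 nM, so the two values stand level within the scatter. Compound 3 (`Cc1ccc2[nH]c(-c3ccc(-c4ccc(-c5ccc(C(F)(F)F)cc5)cc4)cc3)nc2c1`) has trifluoromethyl in place of fluoro on an aromatic carbon, para to a large group: trifluoromethyl in place of fluoro on an aromatic carbon. Within the data shown here, only one measured step bears on this change: a 1.2-fold higher number from compound 1 to compound 2 (0.07 log units; within the scatter), with fluoro in place of hydrogen on an aromatic carbon. Among the measured compounds shown here, that step involves a different exchange, so it offers only indirect guidance, and no measurement yet shows how trifluoromethyl behaves here. Since that single step stayed so small, no change beyond the scatter is expected in this assay. The expected step is a 1.1-fold higher number from compound 2 to compound 3 (0.02 log units; within the scatter). For compound 3 the estimated value is 35000 nM, with an expected range from 15000 nM to 80000 nM.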

Compound 3, concentration for 50% growth inhibition: 38200 nM
Beside the measured number, compound 3's estimate is 1.1-fold (0.04 log units) below it; the range from low to high includes it.
By their numbers in this assay, from the lowest: compounds 1, 2 and 3 (each within the scatter of the next).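

In this assay, the aromatic carbon para to a large group now has a direct reading for trifluoromethyl: the exchange for fluoro gives a 1.2-fold higher number from compound 2 to compound 3 (0.06 log units; within the scatter) and the exchange for hydrogen gives a 1.3-fold higher number from compound 1 to compound 3 (0.13 log units; within the scatter) at the same place. Hydrogen, fluoro and trifluoromethyl therefore stand level within the scatter here, and the earlier pair could not show that this also holds for a group of four heavy atoms. No accompanying evidence accounts for this flat reading.

As far as these compounds go, whether an amine, a carboxylic acid or a longer chain on this carbon would also stand level remains open. Also open, from the compounds shown here alone, is whether trifluoromethyl would read the same on another carbon of this ring.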